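The source may report more compounds than this note shows. Statements on the series, on what has been measured and on what is new or still open speak of the compounds shown alone.

In a functional assay on SF-295 cells (Homo sapiens) for inhibition, read by sulforhodamine B assay, with a stated time of 48 h (a higher number here means a weaker inhibitor of growth, a lower number a stronger inhibitor of growth), the measured compounds are:
compound 1 `COc1ccc(-c2cc(/C=C/C(=O)c3ccc(N)cc3)[nH]n2)cc1` with 3090 nM;
compound 2 `COc1ccc(-c2cc(/C=C/C(=O)c3ccc(N)cc3)[nH]n2)cc1OC` with 3580 nM;
compound 3 `COc1cc(C(=O)/C=C/c2cc(-c3cc(OC)c(OC)c(OC)c3)n[nH]2)cc(OC)c1OC` with "not determined" (no result reported).

From compound 2 to compound 1 the change is hydrogen in place of methoxy on an aromatic carbon and the step is a 1.2-fold lower number from compound 2 to compound 1 (0.06 log units; within the scatter). Compound 4 `COc1ccc(-c2cc(/C=C/C(=O)c3cc(OC)c(OC)c(OC)c3)[nH]n2)cc1OC` is not yet measured; it differs from compound 3 by hydrogen in place of methoxy on an aromatic carbon. How the core of compound 3 differs from that of compound 2 is not broken down here. The two changes are the same kind of change, not the same: in compound 3 the place is also meta to a methoxy group. In this assay the step from compound 3 to compound 4 is expected to be small, beside the earlier one, because a 1.2-fold lower number from compound 2 to compound 1 (0.06 log units; within the scatter) lies within the scatter; with no number for compound 3, the estimate rests on compound 1 and compound 2 alone. Compound 4 is expected to give about 2500 nM, between 400 nM and 15000 nM.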

Compound 4, concentration for 50% growth inhibition: 1670 nM
Compound 4: middle estimate off by 1.5-fold (0.18 log units), on the high side; measured number inside the range.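

No step can be read between compound 3 and compound 4 in this assay: compound 3 has no single number there. The compounds shown leave open how that methoxy group bears on growth inhibition in this assay. Nothing given here accounts for the result of compound 4.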